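A few compounds are considered here, and "the series" means these few. Any claim that something is new, unique, unknown or untested is made for them only; others in the source may bear on it.

Measured so far in an ADME assay on microsomes from liver (Mus musculus) for metabolic stability, with a stated time of 10 min; on this read-out higher numbers stand for a more stable compound and lower numbers for a less stable compound:
- compound 1 (`C[C@]1(C(=O)N2CC[C@](c3ccc(C(F)(C(F)(F)F)C(F)(F)F)cc3)(S(=O)(=O)c3ccc(F)cc3)C2)CC[C@H](C(=O)O)CC1`) with 95% as its result
- compound 2 (`CO[C@]1(C(=O)N2CC[C@](c3ccc(C(F)(C(F)(F)F)C(F)(F)F)cc3)(S(=O)(=O)c3ccc(F)cc3)C2)CC[C@H](C(=O)O)CC1`) with 95% as its result
- compound 3 (`O=C(O)C12CCC(C(=O)N3CC[C@](c4ccc(C(F)(C(F)(F)F)C(F)(F)F)cc4)(S(=O)(=O)c4ccc(F)cc4)C3)(CC1)C2`) with "not determined" (no result reported) as its result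

Compound 3 has no number in this assay, so the step to compound 4 (`O=C(C1CCS(=O)(=O)CC1)N1CC[C@](c2ccc(C(F)(C(F)(F)F)C(F)(F)F)cc2)(S(=O)(=O)c2ccc(F)cc2)C1`) starts from no measured value. Structurally, a group of 8 heavy atoms (5 carbon, 2 oxygen, 1 sulfur; one six-membered non-aromatic ring with 1 hetero atom) in place of a group of 10 heavy atoms (8 carbon, 2 oxygen; 2 five-membered non-aromatic rings of carbon only), on a carbonyl carbon is the change, with 1,1-dioxothian-4-yl as the entering group. Within the data shown here, the only measured step, no change at the digits printed from compound 1 to compound 2 (within the scatter) with methoxy in place of methyl on a saturated ring carbon, lies within the scatter. It is a different change at the same carbonyl-bound part of the series, so it bears only loosely on this one. No size or direction of step can be expected from compound 3 itself. The nearest anchor is compound 2 at 95% in the same read-out, and a value somewhat under it is expected, with wide uncertainty. For compound 4 an estimated 80% is expected, with 55% as the lower end and 97% as the upper end.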

Compound 4, percent of the compound remaining: 96%
For compound 4 the middle estimate is 16 percentage points below the measured one, and the stated range covers the measured number.
By their numbers in this assay, from the lowest: compounds 1, 2 and 4 (each within the scatter of the next).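

On a carbonyl carbon, 1,1-dioxothian-4-yl in place of 4-carboxy-1-methoxycyclohexyl gives in this assay a number 1 percentage points higher from compound 2 to compound 4 (within the scatter), and in place of 4-carboxy-1-methylcyclohexyl it gives a number 1 percentage points higher from compound 1 to compound 4 (within the scatter). Compound 4 carries no carboxylic acid, so across compounds 1, 2 and 4 this read-out does not depend on that group, and the position accepts a six-membered ring with a ring sulfur as well as the substituted cyclohexyl groups. Nothing among the data shown accounts for this outcome.

Open is whether a 4-aminocyclohexyl group or an oxan-4-yl group on the same carbonyl carbon would stay within the scatter of these compounds. Also open, as far as these compounds go, is how far the read-out would fall with a plain cyclohexyl group or an open alkyl chain at this place.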